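This account rests on a few compounds, and the source may have more. Where it says the series, first, only, none or still open, it means among the compounds named here.

Measured in a functional assay on SK-BR-3 cells (Homo sapiens) for antiproliferative activity, read by MTT assay, with a stated time of 72 h; a lower number here means a stronger inhibitor, a higher number a weaker inhibitor:
- Compound 1 `CCNc1cc(C)c2cc(NC(=O)c3ccc(Cl)c(Cl)c3)ccc2n1`: 28200 nM
- Compound 2 `Cc1cc(N2CCCC2)nc2ccc(NC(=O)c3ccc(Cl)c(Cl)c3)cc12`: 43400 nM
- Compound 3 `CCN(CC)c1cc(C)c2cc(NC(=O)c3ccc(Cl)c(Cl)c3)ccc2n1`: 41200 nM

These three values cannot be ranked, since compound 3 sits within the scatter of both neighbours: a 1.5-fold higher number from compound 1 to compound 3 (0.16 log units; within the scatter) and a 1.1-fold lower number from compound 2 to compound 3 (0.02 log units; within the scatter). The remaining pair behaves the same way: a 1.5-fold higher number from compound 1 to compound 2 (0.19 log units; within the scatter).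

Compound 4 `Cc1cc(NCCN2CCN(C)CC2)nc2ccc(NC(=O)c3ccc(Cl)c(Cl)c3)cc12` keeps the shared core but has (2-(4-methylpiperazin-1-yl)ethyl)amino in place of diethylamino on an aromatic carbon, next to the ring nitrogen: (2-(4-methylpiperazin-1-yl)ethyl)amino in place of diethylamino on an aromatic carbon.

All three measured steps bear on this change, as each swaps the group at that same carbon, and none left the scatter. They are only a loose guide, however. For the measured compounds named here, no measured compound carries a six-membered non-aromatic ring with 2 hetero atoms, so the larger group entering here is untested. Like compound 1 at 28200 nM, compound 4 keeps a hydrogen on the nitrogen attached to the core, which gives only a slight lean towards a lower number in this assay.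

Going by the values given here, no step clearly beyond the scatter is therefore expected, and the estimated step is a 1.9-fold lower number from compound 3 to compound 4 (0.27 log units; within the scatter). For compound 4 the estimated value is 22000 nM, with an expected range from 6000 nM to 55000 nM.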

Compound 4, half-maximal inhibitory concentration: 2690 nM
Beside the measured number, compound 4's estimate is 8.2-fold (0.91 log units) above it, outside the stated range (below it).
By their numbers in this assay, from the lowest: compound 4; then compounds 1, 3 and 2 (each within the scatter of the next).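

In this assay, swaps among ethylamino, pyrrolidin-1-yl and diethylamino on this aromatic carbon next to the ring nitrogen stayed within the scatter, but (2-(4-methylpiperazin-1-yl)ethyl)amino shows that the position can respond strongly to its substituent (a 15-fold lower number from compound 3 to compound 4 (1.19 log units; beyond the scatter); a 16-fold lower number from compound 2 to compound 4 (1.21 log units; beyond the scatter)). The comparison with ethylamino is the most telling, as both groups keep a hydrogen on the nitrogen attached to the shared core, so that hydrogen alone does not account for the result, and placing 4-methylpiperazin-1-yl on the chain still gives a large step (a 10-fold lower number from compound 1 to compound 4 (1.02 log units; beyond the scatter)). Nothing in the information available explains why this group has such an effect.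

The compounds shown leave open which part of the entering group matters: the 4-methylpiperazin-1-yl ring as a whole, its methyl group, or the two-carbon chain that holds it. A 2-(dimethylamino)ethylamino group, a morpholine ring on the same chain, or a longer chain carrying the same 4-methylpiperazin-1-yl ring would help separate these parts.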